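The source may hold more compounds than are shown below. What is called first, only, known or untested is meant among the compounds shown, and "the series" means these compounds.

Compound 1 `Cc1cc(NC(=O)c2cc(C(F)(F)F)cc(C(F)(F)F)c2)ccc1NS(C)(=O)=O`: > 250000 nM
Compound 2 `COc1cc(NC(=O)c2cc(C(F)(F)F)cc(C(F)(F)F)c2)ccc1NS(C)(=O)=O`: > 250000 nM
Compound 3 `CS(=O)(=O)Nc1ccc(NC(=O)c2cccc(C(F)(F)F)c2)cc1Cl`: > 250000 nM

Each of these readings in an ADME assay on RAW264.7 cells (Mus musculus) for cytotoxicity, read by MTT assay, with a stated time of 48 h (on this read-out higher numbers stand for weaker inhibition and lower numbers for stronger inhibition), is a limit of the assay, not a measured number. Compound 3 gives > 250000 nM, a limit. Compound 1 gives a limit, > 250000 nM. Compound 2 also gives a limit, > 250000 nM. For the measured compounds named here, the one step between measured compounds, a step that the two limits leave unreadable from compound 1 to compound 2, cannot be read because of the limit of > 250000 nM in this assay, at which 3 of the 3 values shown sit. Compound 4 `CS(=O)(=O)Nc1ccc(NC(=O)c2cc(C(F)(F)F)cc(C(F)(F)F)c2)cc1Cl` differs from compound 3 by trifluoromethyl in place of hydrogen on an aromatic carbon. Going by the values given here, no measured step shows what this change does here, so the expectation rests only on compound 3 and the other two compounds sitting at the limit. Compound 4 is therefore expected to give much the same reading, an estimated step of a number no higher from compound 3 to compound 4 (the limit leaves the size open), most likely again reported as a limit. The estimate for compound 4 is 250000 nM, with a range from 100000 nM to 500000 nM.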

Compound 4, half-maximal inhibitory concentration: 69600 nM
For compound 4 the middle estimate is 3.6-fold (0.56 log units) above the measured one; the whole stated range lies above it.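

In this assay, for the compounds shown here, a second trifluoromethyl on the aromatic ring gives the first reading that is a number and not a limit, with an at least 3.5-fold lower number from compound 3 to compound 4 (0.55 log units; beyond the scatter) as the step. With both trifluoromethyl groups in place, chloro also parts from methoxy and from methyl, with an at least 3.5-fold lower number from compound 2 to compound 4 (0.55 log units; beyond the scatter) and an at least 3.5-fold lower number from compound 1 to compound 4 (0.55 log units; beyond the scatter) as the steps. These steps give only a smallest size, because the starting readings are limits: the limit of > 250000 nM in this assay, at which 3 of the 4 values shown sit.

Going by these compounds, the true size of each step stays open. So does whether a nitrile or an amine in place of the entering trifluoromethyl would lower the number too.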